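Working notes: from compound 2 to compound 4

The compounds below may be only part of what the source reports. "The series", "measured", "known", "first", "only" and "open" are said of these compounds alone.

compound 1 `O=C(NCc1ccc(S(=O)(=O)c2ccccc2)cc1)c1ccc2cnccc2c1`: 10%
compound 2 `O=C(NCc1ccc(S(=O)(=O)N2CCCCC2)cc1)c1cc2ccncc2[nH]1`: "below limit of detection" (no number reported)
compound 3 `O=C(NCc1ccc(S(=O)(=O)c2cc(F)cc(F)c2)cc1)c1cc2cnccc2[nH]1`: 63%

All readings come from an ADME assay on microsomes from liver (Mus musculus) for metabolic stability, read by LC-MS, with a stated time of 30 min, tested at 1 uM; on this read-out lower numbers stand for a less stable compound and higher numbers for a more stable compound. Compound 2 carries no number, and its reading in this assay is "below limit of detection" (no number reported). Compound 1 gives 10% and compound 3 gives 63%, but neither differs from compound 2 in one place only.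

Compound 4 `O=C(NCc1ccc(S(=O)(=O)N2CCCCC2)cc1)c1cc2ccncc2o1` has yet to be measured. The structural change is a group of 9 heavy atoms (7 carbon, 1 nitrogen, 1 oxygen; one five-membered aromatic ring with 1 hetero atom, one six-membered aromatic ring with 1 hetero atom) in place of a group of 9 heavy atoms (7 carbon, 2 nitrogen; one five-membered aromatic ring with 1 hetero atom, one six-membered aromatic ring with 1 hetero atom), on a carbonyl carbon. The rest of the molecule is unchanged.

For the measured compounds named here, no measured pair shows the size of such a swap in this assay. No step beyond the usual scatter is expected, and any movement would more likely be small and upward. This expectation rests on compound 2, whose reading is "below limit of detection" (no number reported). Compound 4 may also return a limit rather than a number.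

For compound 4 the expected value is 8%, with an estimated range from 0% to 30%.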

Compound 4, percent of the compound remaining: 0.14%
The estimate for compound 4 lay 7.9 percentage points above the measured number; the measured number falls inside the stated range.
By their numbers in this assay, from the lowest: compounds 4 and 1 (each within the scatter of the next); then compound 3.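

In this assay, for the compounds shown here, compound 4 gives 0.14% and compound 2 carries no number, and no step between them can be read. The compounds shown leave open what size of change this swap on a carbonyl carbon brings in stability. No data shown bear on a cause for the reading.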